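Swapping cyclohexyl for 1,3-oxazol-4-yl on a carbonyl carbon

A few compounds are considered here, and "the series" means these few. Any claim that something is new, unique, unknown or untested is made for them only; others in the source may bear on it.

Of the compounds shown here, three sharing one core have been measured in a physicochemical assay for lipophilicity, read by HPLC, measured as chromatographic lipophilicity, at pH 7.4; on this read-out lower numbers stand for lower lipophilicity and higher numbers for higher lipophilicity. Compound 3 `O=C(C1CCCCC1)N1CCC(C(=O)N2N=CCC2c2ccccc2)CC1` gives 5.4, the highest of the three numbers. Compound 2 `O=C(C1CCN(C(=O)C(F)(F)F)CC1)N1N=CCC1c1ccccc1` gives 4.9, and compound 1 `O=C(c1cccnc1)N1CCC(C(=O)N2N=CCC2c2ccccc2)CC1` gives 2.6.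

Compound 4 `O=C(c1cocn1)N1CCC(C(=O)N2N=CCC2c2ccccc2)CC1` differs from compound 3 in one place: 1,3-oxazol-4-yl in place of cyclohexyl on a carbonyl carbon. In words, 1,3-oxazol-4-yl stands in place of cyclohexyl on a carbonyl carbon.

For the measured compounds named here, two measured steps bear on this change. Cyclohexyl in place of trifluoromethyl gave a number 0.50 log units higher from compound 2 to compound 3 (beyond the scatter), while cyclohexyl in place of pyridin-3-yl gave a number 2.80 log units higher from compound 1 to compound 3 (beyond the scatter). The second is the closer guide, since pyridin-3-yl, like 1,3-oxazol-4-yl, is an aromatic ring. Running that comparison in reverse, a large drop is expected in this assay, well beyond the scatter. The expected change is a number 2.60 log units lower from compound 3 to compound 4 (beyond the scatter). For compound 4 the estimate is 2.8, with an expected range from 2.2 to 3.4.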

Compound 4, distribution coefficient: 2.9
The estimate for compound 4 lay 0.10 log units below the measured number; measured number inside the range.
By their numbers in this assay, from the lowest: compounds 1 and 4 (each within the scatter of the next); then compound 2; then compound 3.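

In this assay, 1,3-oxazol-4-yl on this carbonyl carbon gives a number 2.50 log units lower from compound 3 to compound 4 (beyond the scatter) when it replaces cyclohexyl, and a number 2.00 log units lower from compound 2 to compound 4 (beyond the scatter) when it replaces trifluoromethyl. Set against pyridin-3-yl, this five-membered aromatic ring with 2 hetero atoms gives a number 0.30 log units higher from compound 1 to compound 4 (within the scatter), so these two aromatic rings cannot be told apart in this assay, even though they differ in ring size and atoms. Nothing on hand gives a reason for these numbers.

Still open, on these data alone, is whether a plain phenyl ring or a thiazole ring at this place would also land with compound 1 and compound 4. Also open, as far as these compounds go, is where a non-aromatic ring holding oxygen, such as tetrahydropyran-4-yl, would fall in the wide gap that separates those two compounds from compound 3.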